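A few compounds are considered here, and "the series" means these few. Any claim that something is new, unique, unknown or untested is made for them only; others in the source may bear on it.

Compound 1 `CC(C)c1n[nH]c2c(NCc3ccc(-c4ccccn4)cc3)nc(SC3CCCCC3O)nc12` is one of three close relatives that share a core and differ only in the group attached to a sulfur. In a functional assay on HT cells (Homo sapiens) for antiproliferative activity, read by fluorescence, with a stated time of 72 h (a higher number here means a weaker inhibitor of growth, a lower number a stronger inhibitor of growth), compound 1 gives 636 nM, the highest number of the three. Compound 2 `CC(C)c1n[nH]c2c(NCc3ccc(-c4ccccn4)cc3)nc(SCC(N)CN)nc12` gives 480 nM, and compound 3 `CC(C)c1n[nH]c2c(NCc3ccc(-c4ccccn4)cc3)nc(SCCn3ccnc3)nc12` gives 155 nM. Compound 4 `CC(=O)NCCSc1nc(NCc2ccc(-c3ccccn3)cc2)c2[nH]nc(C(C)C)c2n1` has not yet been measured; it differs from compound 1 as follows: 2-acetamidoethyl in place of 2-hydroxycyclohexyl on a sulfur. Two measured steps from compound 1 change the same group: a 1.3-fold lower number from compound 1 to compound 2 (0.12 log units; within the scatter), and a 4.1-fold lower number from compound 1 to compound 3 (0.61 log units; beyond the scatter). Both swap the ring for an open chain, and neither raises the number, so a change of similar kind is expected for compound 4: a 1.6-fold lower number from compound 1 to compound 4 (0.20 log units; within the scatter). Compound 4 is therefore estimated at 400 nM, with a likely range from 150 nM to 1100 nM.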

Compound 4, concentration for 50% growth inhibition: 71 nM
The estimate for compound 4 lay 5.6-fold (0.75 log units) above the measured number; measured number outside the range, below it.
By their numbers in this assay, from the lowest: compound 4; then compound 3; then compounds 2 and 1 (each within the scatter of the next).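

Within the data shown here, the group on this sulfur can shift the number further than the earlier compounds showed, since 2-acetamidoethyl in place of 2-hydroxycyclohexyl gives a 9.0-fold lower number from compound 1 to compound 4 (0.95 log units; beyond the scatter). Among the open chains, the end group also counts: there is a 6.8-fold lower number from compound 2 to compound 4 (0.83 log units; beyond the scatter) and also a 2.2-fold lower number from compound 3 to compound 4 (0.34 log units; beyond the scatter). No measured evidence here explains these gains. Still open, going by these compounds, is whether the acetamido group itself matters, or only a chain of this length. A carboxylic acid on the same ethyl chain, or a longer chain ending in acetamido, would help separate the two.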